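A few compounds are considered here, and "the series" means these few. Any claim that something is new, unique, unknown or untested is made for them only; others in the source may bear on it.

Series notes on the shared core, with three compounds measured in an ADME assay on microsomes from liver (Homo sapiens) for metabolic stability, read by LC-MS, using NADPH, with stated times of 5 min and 30 min, tested at 1 uM; on this read-out higher numbers stand for fast clearance and lower numbers for slow clearance. Compound 1 `Cc1ncccc1-c1cnc(NCc2c(F)ccc3c2CCO3)c2n[nH]c(=O)n12` gives 8 mL.min-1.g-1, compound 2 `CC1(C)CC(=O)N(c2cnc(NCc3c(F)ccc4c3CCO4)n3cnnc23)C1` gives 16 mL.min-1.g-1, and compound 3 `Cc1cc(-c2cnc(NCc3c(F)ccc4c3CCO4)c3cn[nH]c(=O)c23)n(C)n1` gives 24 mL.min-1.g-1. Compound 2 stands within the usual scatter of both other compounds, so its number is not separated from either of theirs. Among the compounds with values here, compounds 1, 2 and 3 do not form a pair that differs in one place, and the data therefore hold no measured step to serve as a guide for a small change on the lactam group.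

The next compound is compound 4 `C[C@H]1CC(=O)N(c2cnc(NCc3c(F)ccc4c3CCO4)n3cnnc23)C1`, not yet measured. It differs from compound 2 by a single change, 4-methyl-2-oxopyrrolidin-1-yl in place of 4,4-dimethyl-2-oxopyrrolidin-1-yl on an aromatic carbon, and the entering group has 1 defined stereocentre: 4-methyl-2-oxopyrrolidin-1-yl in place of 4,4-dimethyl-2-oxopyrrolidin-1-yl on an aromatic carbon. The rest of the structure stays the same.

Within the data shown here, with no matching step available, the only anchor in this assay is compound 2 at 16 mL.min-1.g-1, and no shift beyond the scatter is expected in either direction. The expected size of the change is a 1.1-fold lower number from compound 2 to compound 4 (0.06 log units; within the scatter). For compound 4 the estimated value is 14 mL.min-1.g-1, with an expected range from 7 mL.min-1.g-1 to 28 mL.min-1.g-1.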

Compound 4, intrinsic clearance in microsomes: < 3 mL.min-1.g-1
Compound 4 gave a limit, no number (the forecaster's own chance of this, stated with the estimate: 3%); middle value at least 4.6-fold (0.66 log units) away from the limit.
By their numbers in this assay, from the lowest: compounds 1, 2 and 3 (each within the scatter of the next, the first and the last beyond it). At a limit, below all of these: compound 4.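

In this assay the lactam group now has its first measured step: going from 4,4-dimethyl-2-oxopyrrolidin-1-yl to 4-methyl-2-oxopyrrolidin-1-yl, with its 1 defined stereocentre, gives an at least 5.3-fold lower number from compound 2 to compound 4 (0.72 log units; beyond the scatter). Within the data shown here, a change this small on this group, on an aromatic carbon of the six-membered aromatic ring with 2 nitrogen, is therefore enough to move the read-out beyond the scatter, which the three earlier compounds could not show with no pair among them differing in one place. Compound 4 is read as a limit and not a number, so the step has a lower bound but no fixed size: the limit of < 3 mL.min-1.g-1 in this assay, at which 1 of the 4 values shown sits.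

What the other stereoisomer of the 4-methyl group, the unsubstituted 2-oxopyrrolidin-1-yl group or a 4-methoxy group would give in this assay stays open, so the compounds shown do not separate the loss of a methyl from the defined stereocentre. Also open, going by these compounds, is whether the same change would carry over to the cores of compound 1 and compound 3.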